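The source may report more compounds than this note shows. Statements on the series, on what has been measured and on what is new or still open speak of the compounds shown alone.

Of the compounds shown here, three built on one shared core have been tested in a functional assay on HeLa cells (Homo sapiens) for cytotoxicity, read by WST assay, with a stated time of 48 h; on this read-out higher numbers stand for weaker inhibition and lower numbers for stronger inhibition. Compound 1 `COC[C@H](C)[C@H](C)C(c1ccc(O)c(OC)c1)c1ccc(O)c(OC)c1` gives 72000 nM. Compound 2 `COc1cc(C(c2ccc(O)c(OC)c2)[C@@H](C)[C@@H](C)CO)ccc1O` reaches only the limit of the measurement, > 100000 nM, so no number is known for it; this is the limit of > 100000 nM in this assay, at which 1 of the 3 values shown sits. Compound 3 `COc1cc(C(c2ccc(O)c(OC)c2)[C@@H](C)C(C)C)ccc1O` gives 19000 nM, the lowest of the two numbers shown, with compound 1 nearest at a step of a 3.8-fold lower number from compound 1 to compound 3 (0.58 log units; beyond the scatter).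

Compound 4 `COC[C@@H](C)[C@H](C)C(c1ccc(O)c(OC)c1)c1ccc(O)c(OC)c1` has not yet been measured. It differs from compound 3 by methoxy in place of hydrogen on a saturated chain carbon, four bonds along the chain from two aromatic carbons. Going by the values given here, the measured step that bears most directly on this change is the one from compound 1 to compound 3, which removed the same methoxy group at the same place and gave a 3.8-fold lower number from compound 1 to compound 3 (0.58 log units; beyond the scatter). The step from compound 2 to compound 3, an at least 5.2-fold lower number from compound 2 to compound 3 (0.72 log units; beyond the scatter), removed a hydroxy group at that place and moved in the same direction. Putting the methoxy group back onto compound 3 is therefore expected to move the number up by roughly the size seen before, an expected step of a 3.4-fold higher number from compound 3 to compound 4 (0.53 log units; beyond the scatter). For compound 4 the estimate in this assay is 65000 nM, with a likely range from 30000 nM to 140000 nM.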

Compound 4, half-maximal inhibitory concentration: 58000 nM
For compound 4 the middle estimate is 1.1-fold (0.05 log units) above the measured one, and the stated range covers the measured number.
By their numbers in this assay, from the lowest: compound 3; then compounds 4 and 1 (each within the scatter of the next). At a limit, above all of these: compound 2.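

In this assay, the methoxy group at this position now goes with a higher number in a second drawn form, with a 3.1-fold higher number from compound 3 to compound 4 (0.48 log units; beyond the scatter), so the earlier rise seen with compound 1 does not depend on that compound's configuration alone. Inverting the stereocentre at this saturated chain carbon makes no clear difference, with a 1.2-fold lower number from compound 1 to compound 4 (0.09 log units; within the scatter), and this comparison isolates configuration as the only change: the fact that compounds 1 and 4 differ only in the configuration as drawn. The step of an at least 1.7-fold lower number from compound 2 to compound 4 (0.23 log units; that floor lies within the scatter) rests on a limit rather than a number, so the methoxy and hydroxy forms cannot be placed in order from these values: the limit of > 100000 nM in this assay, at which 1 of the 4 values shown sits.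

On these data alone, it remains open whether an amine, a carboxylic acid or a longer chain such as ethoxy at this position would bring the number closer to that of compound 3 or move it further away. The compounds shown also leave open whether the second stereocentre matters, since compound 1 and compound 4 share its drawn configuration and differ only at the other one.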